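Aryl ether series at sigma-1: fluoro step from compound 2

The compounds below may be only part of what the source reports. "The series", "measured", "known", "first", "only" and "open" are said of these compounds alone.

Measured in an assay on isolated protein (Cavia porcellus) with Sigma non-opioid intracellular receptor 1 (Homo sapiens) as the target, read by radioligand binding; a lower number here means a stronger inhibitor, a higher number a weaker inhibitor:
compound 1 `CN(C)CCCCCCCCCCOc1ccc2oc(-c3ccccc3)cc(=O)c2c1`: 297 nM
compound 2 `O=c1cc(-c2ccccc2)oc2ccc(OCCCCCCN3CCC(O)CC3)cc12`: 100 nM
compound 3 `O=c1cc(-c2ccccc2)oc2ccc(OCCCCCCN3CCNC(CCO)C3)cc12`: 63 nM

Compound 2 holds the second highest of the three numbers in this assay. Its nearest neighbour is compound 3, a gap within the scatter (a 1.6-fold lower number from compound 2 to compound 3 (0.20 log units; within the scatter)); its furthest is compound 1, a gap beyond the scatter (a 3.0-fold lower number from compound 1 to compound 2 (0.47 log units; beyond the scatter)). Among the compounds with values here, the one remaining step, a 4.7-fold lower number from compound 1 to compound 3 (0.67 log units; beyond the scatter), is likewise a change at the amine end of the chain.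

Compound 4 `O=c1cc(-c2ccc(F)cc2)oc2ccc(OCCCCCCN3CCC(O)CC3)cc12` differs from compound 2 by fluoro in place of hydrogen on an aromatic carbon. None of the three measured steps touches the aromatic ring at that end of the molecule; all three exchange the group on the chain carbon six bonds from the ether oxygen. Within the data shown here, there is therefore no measured step that bears on this change, and the expectation for the step from compound 2 to compound 4 in this assay is none beyond the scatter: no change at the digits printed from compound 2 to compound 4 (within the scatter). Compound 4 is estimated at 100 nM in this assay, with a range of 40 nM to 250 nM.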

Compound 4, half-maximal inhibitory concentration: 95 nM
Compound 4: middle estimate off by 1.1-fold (0.02 log units), on the high side; the measured number falls inside the stated range.
By their numbers in this assay, from the lowest: compounds 3, 4 and 2 (each within the scatter of the next); then compound 1.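

Phenyl to 4-fluorophenyl is the only step shown away from the amine end of the chain, and in this assay it gives a 1.1-fold lower number from compound 2 to compound 4 (0.02 log units; within the scatter) on the shared core. This step at the aromatic carbon stays within the scatter, unlike the amine-end steps a 3.0-fold lower number from compound 1 to compound 2 (0.47 log units; beyond the scatter) and a 4.7-fold lower number from compound 1 to compound 3 (0.67 log units; beyond the scatter), so this position accepts fluoro in place of hydrogen when the chain ends in 4-hydroxypiperidin-1-yl. Nothing measured here offers a reason for this result.

On these data alone, whether a chloro, methoxy or trifluoromethyl group at the same carbon would also stay within the scatter of compound 2 remains open. Also open, as far as these compounds go, is whether the fluoro step reads the same with the 3-(2-hydroxyethyl)piperazin-1-yl group of compound 3 at the chain end.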